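The source may report more compounds than this note shows. Statements on the series, on what has been measured and on what is new or still open speak of the compounds shown alone.

Compound 1 `c1ccc(-c2cn3ccnc3c(-c3ccc4ncn(C5CCCCC5)c4c3)n2)cc1` is the reference point of this small series. In a functional assay on A549 cells (Homo sapiens) for inhibition, read by sulforhodamine B assay, with a stated time of 48 h, tested at 10 uM (a lower number here means less inhibition, a higher number more inhibition at the concentration tested (going by the name of the read-out)), compound 1 gives 33.3%, the highest of the three numbers measured. Compound 2 `Fc1ccc(-c2cn3ccnc3c(-c3ccc4ncn(C5CCCCC5)c4c3)n2)cc1` gives 12.8%, and compound 3 `c1cn2cc(-c3ccsc3)nc(-c3ccc4ncn(C5CCCCC5)c4c3)c2n1` gives 3.97%. Both steps away from compound 1 are beyond the scatter: a number 20.5 percentage points lower from compound 1 to compound 2 (beyond the scatter) and a number 29.3 percentage points lower from compound 1 to compound 3 (beyond the scatter), while the step of a number 8.8 percentage points lower from compound 2 to compound 3 (within the scatter) is within it.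

Compound 4 `Fc1ccccc1-c1cn2ccnc2c(-c2ccc3ncn(C4CCCCC4)c3c2)n1` is not yet measured. It differs from compound 1 by fluoro in place of hydrogen on an aromatic carbon. The step that bears most directly on this change is a number 20.5 percentage points lower from compound 1 to compound 2 (beyond the scatter), where the same kind of substitution at another place on the same ring lowered the number by a modest amount beyond the scatter. On that basis a decrease of similar character is expected, though the place differs and a single precedent is a thin basis. The estimate for compound 4 is therefore 18%, with a range from 4% to 36%, which means an expected step of a number 15.3 percentage points lower from compound 1 to compound 4 (beyond the scatter).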

Compound 4, a percentage reported as inhibition, at one concentration (the size of the read-out at that concentration, not a potency): 9.1%
Estimate against measurement, compound 4: 8.9 percentage points above, within the range that was stated.
By their numbers in this assay, from the lowest: compounds 3, 4 and 2 (each within the scatter of the next); then compound 1.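

In this assay, a fluoro on the phenyl ring, here ortho to a large group, again goes with a lower number (a number 24.2 percentage points lower from compound 1 to compound 4 (beyond the scatter)), so compound 1 now stands apart from two fluorinated analogues with the fluoro at different places. The place of the fluoro does not separate these two analogues (a number 3.7 percentage points lower from compound 2 to compound 4 (within the scatter)), and 2-fluorophenyl is not separated from thiophen-3-yl either (a number 5.1 percentage points higher from compound 3 to compound 4 (within the scatter)). Nothing available explains why these changes lower the number.

From the compounds shown here alone, it remains open whether a chloro, a methoxy or an amine at these places on the phenyl ring would also lower the number, or whether the fall is seen with fluoro alone. Also open, going by these compounds, is how a pyridyl in place of the phenyl would compare with compound 1.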